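A few compounds are considered here, and "the series" means these few. Any claim that something is new, unique, unknown or untested is made for them only; others in the source may bear on it.

Measured in an ADME assay on liver (Mus musculus) for metabolic stability, read by LC-MS, using microsomes and NADPH; a lower number here means that less of the compound is left, a higher number that more of the compound is left:
- compound 1 `CCCN(Cc1ccc(OCCn2c(=O)ccn(C)c2=O)c(OC)c1)C(CC(=O)O)c1ccc(Cl)cc1` gives 50%
- compound 2 `COc1cc(CN(CC2CC2)C(CC(=O)O)c2ccc(Cl)cc2)ccc1OCCn1c(=O)ccn(C)c1=O` gives 42%
- compound 3 `COc1cc(CN(C2CCC2)C(CC(=O)O)c2ccc(Cl)cc2)ccc1OCCn1c(=O)ccn(C)c1=O` gives 51%

At 51%, compound 3 lies within the scatter of both other compounds, so the three form a single group on these numbers. The next compound, compound 4 `CCCCN(Cc1ccc(OCCn2c(=O)ccn(C)c2=O)c(OC)c1)C(CC(=O)O)c1ccc(Cl)cc1`, carries butyl in place of cyclobutyl on an amine nitrogen.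

The closest measured change is cyclobutyl in place of propyl on an amine nitrogen, a number 1 percentage points higher from compound 1 to compound 3 (within the scatter). Cyclobutyl in place of cyclopropylmethyl gave a number 9 percentage points higher from compound 2 to compound 3 (within the scatter), and cyclopropyl in place of ethyl gave a number 8 percentage points lower from compound 1 to compound 2 (within the scatter). All three steps stay within the scatter, so swapping between these groups has not yet moved the number measurably. No step beyond the scatter is therefore expected here, and no direction can be firmly expected either. The expected step is a number 5 percentage points lower from compound 3 to compound 4 (within the scatter). For compound 4 the estimated value is 46%, with an expected range from 33% to 58%.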

Compound 4, percent of the compound remaining: 37%
The estimate for compound 4 lay 9 percentage points above the measured number; low and high end bracket the measured number.
By their numbers in this assay, from the lowest: compounds 4, 2, 1 and 3 (each within the scatter of the next, the first and the last beyond it).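

In this assay, the position on the amine nitrogen now gives its first steps beyond the scatter: butyl in place of cyclobutyl gives a number 14 percentage points lower from compound 3 to compound 4 (beyond the scatter), although the count of carbons stays the same and only the ring is lost. Extending the propyl of compound 1 by one methyl gives a number 13 percentage points lower from compound 1 to compound 4 (beyond the scatter), so the length of the open chain also matters in this pair. The cyclopropylmethyl of compound 2 does not separate from butyl, as propyl in place of cyclopropyl gives a number 5 percentage points lower from compound 2 to compound 4 (within the scatter), which means that the open chains and ring-bearing groups do not fall into two clean classes.

Nothing shown explains these steps. On these data alone, it remains open whether a longer chain such as pentyl would continue the trend from propyl to butyl, and whether a larger ring such as cyclopentyl would match cyclobutyl.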